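This account rests on a few compounds, and the source may have more. Where it says the series, first, only, none or still open, it means among the compounds named here.

Measured so far in a functional assay on A549 cells (Homo sapiens) for cytotoxicity, read by MTT assay, with a stated time of 72 h; a lower number here means a stronger inhibitor, a higher number a weaker inhibitor:
- compound 1 `CC(=O)n1cc(/C=C(/C(=O)O)c2ccc(OCc3ccccc3)cc2)c2cc(OCc3ccccc3)ccc21`: 44100 nM
- compound 2 `CC(=O)n1cc(/C=C(/C(=O)O)c2ccc(Cl)cc2)c2cc(OCc3ccccc3)ccc21`: 52300 nM

Compound 2 holds the highest of the two numbers, with compound 1 at a 1.2-fold higher number from compound 1 to compound 2 (0.07 log units; within the scatter) from it. Compound 3 `COc1ccc(/C(=C\c2cn(C(C)=O)c3ccc(OCc4ccccc4)cc23)C(=O)O)cc1` differs from compound 2 by methoxy in place of chloro on an aromatic carbon. Among the compounds with values here, the only step in this assay that bears on the same aromatic carbon is a 1.2-fold higher number from compound 1 to compound 2 (0.07 log units; within the scatter), where two rather different groups gave numbers within the scatter. Compound 3 is therefore expected to shift by a 1.0-fold lower number from compound 2 to compound 3 (0.02 log units; within the scatter), no direction beyond the scatter. The estimate for compound 3 in this assay is 50000 nM, with a range of 20000 nM to 125000 nM.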

Compound 3, half-maximal inhibitory concentration: > 100000 nM
Compound 3: no number, only a limit (the forecaster's own chance of this, stated with the estimate: 20%); middle value at least 2.0-fold (0.30 log units) away from the limit.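

In this assay compound 3 gives > 100000 nM, which is a limit and not a number. The position is not indifferent to its group: methoxy in place of benzyloxy gives an at least 2.2-fold higher number from compound 1 to compound 3 (0.35 log units; beyond the scatter), while the step against chloro, an at least 1.9-fold higher number from compound 2 to compound 3 (0.28 log units; that floor lies within the scatter), has a floor that does not clear the scatter. The true size of both steps stays unread, since only a floor is available: the limit of > 100000 nM in this assay, at which 1 of the 3 values shown sits.

Open, from the compounds shown here alone, is whether a smaller group such as hydroxyl, or an amine, on this aromatic carbon gives a measurable number. Also open, going by these compounds, is whether an ethoxy chain reads closer to methoxy or to benzyloxy.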